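The compounds below may be only part of what the source reports. "The series", "measured", "known", "first", "only" and "open" are said of these compounds alone.

In a functional assay on DU-145 cells (Homo sapiens) for inhibition, read by trypan blue exclusion, with a stated time of 72 h (a higher number here means a weaker inhibitor, a lower number a stronger inhibitor), two compounds sharing one core have been measured so far. Compound 1 `Cc1ccc(S(=O)(=O)c2cc3cnc(Nc4cnc5c(c4)CC(=O)N5)nc3n(C)c2=O)cc1` gives 15000 nM and compound 2 `Cc1ccc(S(=O)(=O)c2cc3cnc(Nc4ccc5[nH]ccc5c4)nc3n(C)c2=O)cc1` gives 750 nM, the lower of the two numbers and so the stronger inhibitor. Compound 3 `Cc1ccc(S(=O)(=O)c2cc3cnc(Nc4ccc5ncccc5c4)nc3n(C)c2=O)cc1` keeps the core and changes one group: quinolin-6-yl in place of 1H-indol-5-yl on a nitrogen on an aromatic ring. Within the data shown here, the only measured step that bears on this, a 20-fold lower number from compound 1 to compound 2 (1.30 log units; beyond the scatter), was large and changed the group at that same place, so a change here can matter. It is a single comparison, however, and neither of its groups is quinolin-6-yl. A modest rise is expected, estimated as a 2.0-fold higher number from compound 2 to compound 3 (0.30 log units; within the scatter), though a smaller change than the measured one. For compound 3 the estimated value in this assay is 1500 nM, with an expected range from 400 nM to 6000 nM.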

Compound 3, half-maximal inhibitory concentration: 10000 nM
The estimate for compound 3 lay 6.7-fold (0.82 log units) below the measured number; the whole stated range lies below it.
By their numbers in this assay, from the lowest: compound 2; then compounds 3 and 1 (each within the scatter of the next).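

In this assay, the step of a 13-fold higher number from compound 2 to compound 3 (1.12 log units; beyond the scatter) shows that this position responds strongly even when one two-ring group replaces another, so the earlier gain does not carry over to quinolin-6-yl. With a 1.5-fold lower number from compound 1 to compound 3 (0.18 log units; within the scatter) inside the scatter, 1H-indol-5-yl alone stands apart among these three groups, and compound 2 remains the strongest inhibitor of the three. No measurement here explains the rise.

The change alters the ring size, the hydrogen-bond donor and the hydrogen-bond acceptor together, so these compounds cannot show which of them matters. A plain phenyl group or a 1-methyl-1H-indol-5-yl group on the same nitrogen would be needed to tell whether a low number here requires the 1H-indol-5-yl group itself.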